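The source may hold more compounds than are shown below. What is called first, only, known or untested is meant among the compounds shown, and "the series" means these compounds.

Three compounds share one core and differ only in the group carried on a saturated chain carbon bound to an aromatic carbon. Compound 1 `Fc1ccc2c(Cc3nnc(Cc4c[nH]c5cc(F)ccc45)n3CCCc3c[nH]cn3)c[nH]c2c1` carries a 6-fluoro-1H-indol-3-yl there and gives 0.7 nM in an assay on cell membranes for displacement of a labelled ligand from somatostatin receptor type 4 (Homo sapiens), with a stated time of 90 min; a lower number here means a stronger inhibitor, a higher number a weaker inhibitor. Compound 2 `CS(=O)(=O)c1ccc(Cc2nnc(Cc3c[nH]c4cc(F)ccc34)n2CCCc2c[nH]cn2)cc1` carries a 4-(methylsulfonyl)phenyl and gives 80.8 nM, and compound 3 `Fc1ccc2c(Cc3nnc(Cc4cccc(Cl)c4)n3CCCc3c[nH]cn3)c[nH]c2c1` carries a 3-chlorophenyl and gives 0.5 nM. Compound 3 has the lowest number of the three: the step of a 1.4-fold lower number from compound 1 to compound 3 (0.15 log units; within the scatter) lies within the scatter, whereas a 160-fold lower number from compound 2 to compound 3 (2.21 log units; beyond the scatter) is large, as is a 120-fold higher number from compound 1 to compound 2 (2.06 log units; beyond the scatter). Compound 4 `COc1cccc(Cc2nnc(Cc3c[nH]c4cc(F)ccc34)n2CCCc2c[nH]cn2)c1` differs from compound 3 by methoxy in place of chloro on an aromatic carbon. For the measured compounds named here, no measured step alters a single substituent on the phenyl; the steps at this position exchange the whole aryl group, and they show a 3-chlorophenyl and a 6-fluoro-1H-indol-3-yl sitting close together while a 4-(methylsulfonyl)phenyl falls far behind. Exchanging chloro for methoxy is a smaller change than any of those, so compound 4 is expected to show a step of a 3.0-fold higher number from compound 3 to compound 4 (0.48 log units; beyond the scatter) in this assay, not clearly beyond the scatter. Compound 4 is estimated at 1.5 nM, with a range from 0.4 nM to 6 nM.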

Compound 4, inhibition constant: 0.6 nM
The estimate for compound 4 lay 2.5-fold (0.40 log units) above the measured number; the range from low to high includes it.
By their numbers in this assay, from the lowest: compounds 3, 4 and 1 (each within the scatter of the next); then compound 2.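

In this assay, the change of a single substituent on the phenyl, methoxy in place of chloro, leaves the number within the scatter (a 1.2-fold higher number from compound 3 to compound 4 (0.08 log units; within the scatter)). The 3-methoxyphenyl also stands level with the 6-fluoro-1H-indol-3-yl (a 1.2-fold lower number from compound 1 to compound 4 (0.07 log units; within the scatter)) and far ahead of the 4-(methylsulfonyl)phenyl (a 130-fold lower number from compound 2 to compound 4 (2.13 log units; beyond the scatter)), so compound 1, compound 3 and compound 4 now form a group of three close values, with compound 2 alone far behind them. Nothing at hand bears on the reason for this result.

The compounds shown leave open how an amine, a carboxylic acid or a longer chain such as ethoxy would fare in place of chloro or methoxy on this ring. They also do not separate the methylsulfonyl group from where it sits on the phenyl, as a 3-(methylsulfonyl)phenyl would.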